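Working notes: the nitrogen substituent, from compound 3 to compound 4

This account rests on a few compounds, and the source may have more. Where it says the series, first, only, none or still open, it means among the compounds named here.

Compound 1 `CCOC(=O)c1cnc(NC2CCCC2)n2nc(-c3ccco3)nc12`, in an assay on CHO cells for displacement of a labelled ligand from adenosine receptor A1 (Homo sapiens); on this read-out lower numbers stand for stronger inhibition and higher numbers for weaker inhibition: 34.4 nM.
Compound 2 `CCOC(=O)c1cnc(NCCOC)n2nc(-c3ccco3)nc12`, in this assay: 2270 nM.
Compound 3 `CNc1ncc(C(=O)O)c2nc(-c3ccco3)nn12`, in this assay: > 100000 nM, a limit of the assay and not a number.

Compound 3 thus stands at the limit of > 100000 nM in this assay, at which 1 of the 3 values shown sits, with no number of its own. Compound 4 `Cc1ccc(CNc2ncc(C(=O)O)c3nc(-c4ccco4)nn23)cc1` differs from it by 4-methylphenyl in place of hydrogen on a saturated chain carbon bound to a nitrogen on an aromatic ring. For the measured compounds named here, the only measured step on the substituent at the ring nitrogen is a 66-fold higher number from compound 1 to compound 2 (1.82 log units; beyond the scatter), where the carbocyclic group went with the lower number. In this assay a lower number is therefore expected for compound 4, though from a limit the size of the step cannot be fixed. Compound 4 is expected near 20000 nM, within 3000 nM to 100000 nM, which would mean an at least 5.0-fold lower number from compound 3 to compound 4 (0.69 log units; beyond the scatter).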

Compound 4, inhibition constant: 2730 nM
The estimate for compound 4 lay 7.3-fold (0.86 log units) above the measured number; measured number outside the range, below it.
By their numbers in this assay, from the lowest: compound 1; then compounds 2 and 4 (each within the scatter of the next). At a limit, above all of these: compound 3.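

With the carboxylic acid on the shared core, the nitrogen substituent still moves the read-out in this assay: 4-methylbenzyl in place of methyl gives an at least 36-fold lower number from compound 3 to compound 4 (1.56 log units; beyond the scatter). For the compounds shown here, the sensitivity to this substituent, earlier seen only with the ethyl ester, therefore also holds with the acid. As far as these compounds go, compound 3 sits at a limit of the assay and not at a number, so the true size of this step stays unknown: the limit of > 100000 nM in this assay, at which 1 of the 4 values shown sits.

Open, from the compounds shown here alone, is whether a plain benzyl group would serve as well as 4-methylbenzyl. Also open, going by these compounds, is how cyclopentyl on the nitrogen would read with the carboxylic acid in place of the ethyl ester.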